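The compounds below may be only part of what the source reports. "The series", "measured", "known", "first", "only" and "open" are said of these compounds alone.

Measured compounds:
Compound 1, `C[C@H]1O[C@@H](n2ccc(=O)[nH]c2=O)C=C(F)C1=O`, gives 2200 nM in a functional assay on CCRF-CEM cells (Homo sapiens) for cytotoxicity; on this read-out higher numbers stand for weaker inhibition and lower numbers for stronger inhibition.
Compound 2, `C[C@H]1O[C@@H](n2cc(F)c(=O)[nH]c2=O)C=C(F)C1=O`, gives 3700 nM in this assay.

Compound 2 holds the highest of the two numbers in this assay; its nearest neighbour is compound 1, and the step of a 1.7-fold higher number from compound 1 to compound 2 (0.23 log units; within the scatter) lies within the scatter, so the two cannot be told apart on these data. Compound 3, `Cc1cn([C@H]2C=C(F)C(=O)[C@@H](C)O2)c(=O)[nH]c1=O`, differs from compound 2 by methyl in place of fluoro on an aromatic carbon. Among the measured compounds shown here, the only measured step touches the same aromatic carbon: it swapped hydrogen for fluoro, and a 1.7-fold higher number from compound 1 to compound 2 (0.23 log units; within the scatter) shows that this position tolerated the exchange without a shift beyond the scatter. For the measured compounds named here, no measured step shows methyl at this place, so the expectation rests on that single comparison. A step of no more than the usual scatter is therefore expected, with no clear direction, and compound 3 is estimated at 3000 nM (range 1200 nM to 8000 nM), which means an expected step of a 1.2-fold lower number from compound 2 to compound 3 (0.09 log units; within the scatter).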

Compound 3, half-maximal inhibitory concentration: 2600 nM
Compound 3: middle estimate off by 1.2-fold (0.06 log units), on the high side; measured number inside the range.
By their numbers in this assay, from the lowest: compounds 1, 3 and 2 (each within the scatter of the next).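

The earlier compounds shown here showed only that fluoro could replace hydrogen on this aromatic carbon. Compound 3 adds a carbon-based group to that picture: methyl in place of fluoro gives (a 1.4-fold lower number from compound 2 to compound 3 (0.15 log units; within the scatter)), and methyl in place of hydrogen gives (a 1.2-fold higher number from compound 1 to compound 3 (0.07 log units; within the scatter)), so in this assay hydrogen, fluoro and methyl cannot be told apart at this position. No available evidence accounts for this flat result.

The compounds shown leave open whether any group on this carbon can move the number beyond the scatter, and in which direction. An amine, a carboxylic acid or a longer chain such as propyl would test this, since each differs from hydrogen, fluoro and methyl in its atoms or its length.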